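Pyridin-3-yl in place of phenyl on the oxadiazole

The source may report more compounds than this note shows. Statements on the series, on what has been measured and on what is new or still open speak of the compounds shown alone.

Compound 1 `CS(=O)(=O)c1ccc(-c2cnc3[nH]cc(-c4nnc(-c5ccccc5)o4)c(=O)c3c2)cc1`: 15.7%
Compound 2 `O=c1c(-c2nnc(-c3ccc(F)cc3)o2)c[nH]c2ncc(-c3cccnc3)cc12`: 19.7%

In a functional assay on HCT-116 cells (Homo sapiens) for inhibition, read by MTT assay, with a stated time of 24 h, tested at 10 uM (a higher number here means more inhibition of growth at the concentration tested, a lower number less inhibition of growth), compound 1 gives 15.7%. For the measured compounds named here, compound 2, the only other measured compound, gives 19.7% in this assay, and the two numbers lie within the scatter of each other, so compound 1 stands level with it. Compound 3 `CS(=O)(=O)c1ccc(-c2cnc3[nH]cc(-c4nnc(-c5cccnc5)o4)c(=O)c3c2)cc1` differs from compound 1 by pyridin-3-yl in place of phenyl on an aromatic carbon. Going by the values given here, no step between measured compounds covers this change, so no change beyond the scatter is expected. For compound 3 the estimate is 17%, within 5% to 35%. That estimate means a step of a number 1.3 percentage points higher from compound 1 to compound 3 (within the scatter).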

Compound 3, percent growth inhibition at one concentration: 14.7%
For compound 3 the middle estimate is 2.3 percentage points above the measured one; measured number inside the range.
By their numbers in this assay, from the lowest: compounds 3, 1 and 2 (each within the scatter of the next).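

For the compounds shown here, with pyridin-3-yl in place of phenyl on the aromatic carbon of the five-membered aromatic ring, this assay records a number 1 percentage points lower from compound 1 to compound 3 (within the scatter) and gives the first reading of a single change at this position. The ring nitrogen that enters thus leaves the growth inhibition at this one concentration unchanged within the scatter. No available evidence bears on this result. Going by these compounds, whether an amine or a carboxylic acid on the pyridin-3-yl ring would move the number remains open, as does the effect of a longer chain in place of the ring.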